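Chain shortening on two cores and cytotoxicity

The compounds below may be only part of what the source reports. "The series", "measured", "known", "first", "only" and "open" are said of these compounds alone.

Compound 3 `CCCCCCCc1cc2cn(COCCO)c(=O)nc2o1` and compound 1 `CCCCc1cc2cn(COCCO)c(=O)nc2o1` share one core and differ only in the chain: hydrogen in place of propyl on a saturated chain carbon, four bonds along the chain from an aromatic carbon. In a functional assay on HEL cells (Homo sapiens), read by microscopy (on this read-out higher numbers stand for lower toxicity in this test and lower numbers for higher toxicity in this test), compound 3 gives 400000 nM. Compound 1 reaches only the limit of this assay, > 400000 nM, which is not a number. The step of a number no lower from compound 3 to compound 1 (the limit leaves the size open) therefore has no readable size, resting as it does on (the limit of > 400000 nM in this assay, at which 1 of the 3 values shown sits). Compound 2 `CCCCCCCCCCCc1cc2cn(COCCO)c(O)nc-2n1` stands on another core; how the two cores differ is not broken down here. In this assay compound 2 gives 80000 nM, the lowest of the two numbers read, with compound 3 standing beyond the scatter above it.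

Compound 4 `CCCCCCCCc1cc2cn(COCCO)c(O)nc-2n1` is not yet measured. It differs from compound 2 by hydrogen in place of propyl on a saturated chain carbon, eight bonds along the chain from an aromatic carbon. This is the same kind of change as from compound 3 to compound 1, but the place differs: eight bonds along the chain from an aromatic carbon rather than four, and on the other core. Since the measured step of this kind only reached a limit, its direction toward a higher number is taken as the guide, without a firm size. Compound 4 is expected to give about 200000 nM in this assay. That expectation means a step of a 2.5-fold higher number from compound 2 to compound 4 (0.40 log units; beyond the scatter). The estimate for compound 4 is taken to lie between 80000 nM and 400000 nM.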

Compound 4, minimum cytotoxic concentration: 80000 nM
Compound 4: middle estimate off by 2.5-fold (0.40 log units), on the high side, and the stated range covers the measured number.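

In this assay, hydrogen in place of propyl on the core of compound 2, on a saturated chain carbon eight bonds along the chain from an aromatic carbon, gives no change at the digits printed from compound 2 to compound 4 (within the scatter), so this read-out does not separate the two chains on this core. Carrying the change over from the other core shows neither agreement nor disagreement, and the two steps also differ in place, four bonds along the chain rather than eight, so the effects of core and place are not separated: the same change on two cores in this assay, a number no lower (the limit leaves the size open) from compound 3 to compound 1 and no change at the digits printed (within the scatter) from compound 2 to compound 4; the limit leaves it open whether they differ. The step on the core of compound 1 has no readable size, as compound 1 stands at a limit of the assay: the limit of > 400000 nM in this assay, at which 1 of the 4 values shown sits.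

The compounds shown leave open whether chains of matching length on the two cores would read alike in this assay, which would compare the cores directly. They also leave open how a chain ending in an amine or a carboxylic acid, or a longer chain on the core of compound 1, would read.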